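From Octyl to Phenyl on a Sulfur

A few compounds are considered here, and "the series" means these few. Any claim that something is new, unique, unknown or untested is made for them only; others in the source may bear on it.

Values in a functional assay on HeLa cells (Homo sapiens) for cytotoxicity; on this read-out lower numbers stand for stronger inhibition and higher numbers for weaker inhibition:
- Compound 1 `CCCCCCCCSC1=CC(=O)C(C[C@]2(C)[C@@H](C)CC[C@]3(C)C(C)=CCC[C@@H]23)=CC1=O`: > 100000 nM, a limit
- Compound 2 `CC1CCC[C@H]2[C@](C)(CC3=CC(=O)C(Cl)=CC3=O)[C@@H](C)CC[C@]12C`: 34100 nM
- Compound 3 `CC1=CCC[C@H]2[C@](C)(CC3=CC(=O)C4=C(SCCS4)C3=O)[C@@H](C)CC[C@]12C`: > 100000 nM, a limit

Compound 1 gives no true number, and its value is only a limit of the assay. It sits on (the limit of > 100000 nM in this assay, at which 2 of the 3 values shown sit), and compound 3 is the other entry there. Compound 2 is the only one of the three with a measured number, 34100 nM.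

The next compound to be tested is compound 4 `CC1=CCC[C@H]2[C@](C)(CC3=CC(=O)C(Sc4ccccc4)=CC3=O)[C@@H](C)CC[C@]12C`. It keeps the core of compound 1 and carries phenyl in place of octyl on a sulfur. Within the data shown here, no pair of measured compounds differs in just one place, so no measured step shows how large such a change tends to be.

In this assay a modest shift towards stronger inhibition is expected, although the result could again stop at the limit. Compound 2, at 34100 nM, shows that a number can be reached in this small set, and the expectation leans towards that region. The estimated change is an at least 2.2-fold lower number from compound 1 to compound 4 (0.34 log units; beyond the scatter). For compound 4 the estimated value is 45000 nM, with an expected range from 12000 nM to 100000 nM.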

Compound 4, half-maximal inhibitory concentration: 45000 nM
The estimate for compound 4 equals the measured number at the digits printed, and the stated range covers the measured number.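

In this assay, replacing octyl with phenyl on the sulfur gives an at least 2.2-fold lower number from compound 1 to compound 4 (0.34 log units; beyond the scatter), so the group carried on this sulfur can move a compound off the limit and onto a measured number. Compound 1 gives > 100000 nM, which is a limit and not a number. The step can be read only as a minimum and its full size stays unknown, because compound 1 sits at that limit: the limit of > 100000 nM in this assay, at which 2 of the 4 values shown sit.

This single pair cannot separate the effect of having an aromatic ring on the sulfur from the effect of losing the octyl chain, as both happen in the same change. Going by these compounds, how a butyl chain, a cyclohexyl ring or a substituted phenyl such as 4-chlorophenyl would read on this sulfur remains open.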